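The compounds below may be only part of what the source reports. "The series", "measured", "known", "first", "only" and "open" are said of these compounds alone.

In a functional assay on MKN-45 cells (Homo sapiens) for antiproliferative activity, read by MTT assay, with a stated time of 72 h, tested at 10 uM (a higher number here means more inhibition at the concentration tested (going by the name of the read-out), a lower number less inhibition), three compounds have been measured:

Compound 1, `O=C(Nc1cc(Oc2ccc(Nc3nccc4[nH]cc(-c5ccc(F)cc5)c(=O)c34)cc2F)ccn1)C1CCC1`, gives 52.8%.
Compound 2, `O=C(Nc1cc(Oc2ccc(Nc3nccc4[nH]cc(-c5ccc(F)cc5)c(=O)c34)cc2F)ccn1)C1CC1`, gives 81.8%.
Compound 3, `CC(C)(O)Cn1cc(-c2ccc(F)cc2)c(=O)c2c(Nc3ccc(Oc4ccnc(NC(=O)C5CC5)c4)c(F)c3)nccc21`, gives 44.3%.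

Compound 2 stands highest of the three; the nearer of the other two is compound 1 and the further is compound 3, both beyond the scatter, as the steps of a number 29 percentage points higher from compound 1 to compound 2 (beyond the scatter) and a number 37.5 percentage points lower from compound 2 to compound 3 (beyond the scatter) show. Compound 4, `CCCC(=O)Nc1cc(Oc2ccc(Nc3nccc4[nH]cc(-c5ccc(F)cc5)c(=O)c34)cc2F)ccn1`, has not been measured. It differs from compound 2 in one place: propyl in place of cyclopropyl on a carbonyl carbon.

Within the data shown here, only one measured step bears on this position, the carbonyl carbon: a number 29 percentage points higher from compound 1 to compound 2 (beyond the scatter), a modest change when one ring replaced another there. The step from compound 2 to compound 3 touches a different place and gives no guidance. Since a change at the carbonyl carbon has moved the read-out by a modest amount once, and compound 2 already sits at the top, a modest decrease is expected rather than a gain, with considerable uncertainty. For compound 4 the expected value is 65%, within 45% to 85%. This estimate corresponds to a step of a number 16.8 percentage points lower from compound 2 to compound 4 (beyond the scatter).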

Compound 4, a percentage reported as inhibition, at one concentration (the size of the read-out at that concentration, not a potency): 64.6%
Compound 4: middle estimate off by 0.4 percentage points, on the high side; the measured number falls inside the stated range.
By their numbers in this assay, from the lowest: compounds 3 and 1 (each within the scatter of the next); then compound 4; then compound 2.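

In this assay, the change from cyclopropyl to propyl keeps the same count of carbon atoms on the carbonyl carbon and only opens the ring, yet this alone gives a number 17.2 percentage points lower from compound 2 to compound 4 (beyond the scatter). The open chain nevertheless gives a number 11.8 percentage points higher from compound 1 to compound 4 (beyond the scatter), so a ring at this place does not by itself raise the read-out: cyclopropyl stands above propyl and cyclobutyl below it. No measurement shown here explains this order.

From the compounds shown here alone, it remains open how a shorter chain such as ethyl, a branched one such as isopropyl, or an amine on the carbonyl carbon would compare with these three groups. Going by these compounds, it is also open whether the same order would hold with the 2-hydroxy-2-methylpropyl group of compound 3 on the aromatic nitrogen.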